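Swapping a triazole for a piperidine on the shared core

The compounds below may be only part of what the source reports. "The series", "measured", "known", "first", "only" and "open" are said of these compounds alone.

Compounds measured in a toxicity assay on L02 cells (Homo sapiens) for cytotoxicity, read by MTT assay, with a stated time of 72 h; on this read-out higher numbers stand for weaker inhibition and lower numbers for stronger inhibition:
compound 1 `O=C1c2c[n+]([O-])c3ccccc3c2C(=O)c2c1c1ccccc1n2Cc1cn(CC(O)CO)nn1` gives 1070 nM
compound 2 `O=C1c2c[n+]([O-])c3ccccc3c2C(=O)c2c1c1ccccc1n2CCN1CCCC1` gives 930 nM
compound 3 `O=C1c2c[n+]([O-])c3ccccc3c2C(=O)c2c1c1ccccc1n2Cc1cn(C[C@H](O)CO)nn1` gives 1130 nM

Compound 3 sits close to both others: the gap a 1.1-fold higher number from compound 1 to compound 3 (0.02 log units; within the scatter) and the gap a 1.2-fold higher number from compound 2 to compound 3 (0.08 log units; within the scatter) are each within the scatter, so the three numbers cannot be told apart. Compound 4 `O=C1c2c[n+]([O-])c3ccccc3c2C(=O)c2c1c1ccccc1n2CCN1CCCCC1` differs from compound 3 as follows: (piperidin-1-yl)methyl in place of 1-(2,3-dihydroxypropyl)-1H-1,2,3-triazol-4-yl on a saturated chain carbon bound to an aromatic nitrogen. The nearest measured guide is the exchange of the triazole for a saturated amine ring, seen as a 1.2-fold lower number from compound 1 to compound 2 (0.06 log units; within the scatter) and a 1.2-fold higher number from compound 2 to compound 3 (0.08 log units; within the scatter), both within the scatter. A step of the same kind is therefore expected to leave this assay essentially unchanged, a 1.2-fold lower number from compound 3 to compound 4 (0.08 log units; within the scatter). Compound 4 is estimated at 950 nM, with a range from 500 nM to 1800 nM.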

Compound 4, half-maximal inhibitory concentration: 1050 nM
Compound 4: middle estimate off by 1.1-fold (0.04 log units), on the low side; low and high end bracket the measured number.
By their numbers in this assay, from the lowest: compounds 2, 4, 1 and 3 (each within the scatter of the next).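

In this assay, widening the saturated amine ring from pyrrolidin-1-yl to piperidin-1-yl makes no readable difference (a 1.1-fold higher number from compound 2 to compound 4 (0.05 log units; within the scatter)). Exchanging the triazole group for (piperidin-1-yl)methyl also stays within the scatter, whether the triazole compound has a drawn stereocentre (a 1.1-fold lower number from compound 3 to compound 4 (0.03 log units; within the scatter)) or not (a 1.0-fold lower number from compound 1 to compound 4 (0.01 log units; within the scatter)), so the four compounds cannot be told apart here. Nothing given here accounts for this result.

Still open, as far as these compounds go, is whether a carboxylic acid or a dimethylamino group in this place would give a similar number. From the compounds shown here alone, a longer chain between the aromatic nitrogen and the amine is equally open.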